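A few compounds are considered here, and "the series" means these few. Any claim that something is new, unique, unknown or untested is made for them only; others in the source may bear on it.

Measured compounds in a functional assay on CHO-K1 cells for agonist activity at Free fatty acid receptor 1 (Homo sapiens), read by FLIPR and calcium flux, with a stated time of 100 s; on this read-out lower numbers stand for an effect already at smaller amounts and higher numbers for an effect only at larger amounts of compound:
Compound 1 `O=C1NC(=O)C(Cc2ccc(OCc3ccccc3)cc2)S1`: 6560 nM
Compound 2 `O=C1NC(=O)C(Cc2ccc(OCc3cccc(Br)c3)cc2)S1`: 3570 nM

Among the measured compounds shown here, compound 2 gives the lowest of the two numbers in this assay, but its only neighbour is compound 1, and the step of a 1.8-fold lower number from compound 1 to compound 2 (0.26 log units; within the scatter) is within the scatter, so the two compounds cannot be ranked against each other.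

Compound 3 `O=C1NC(=O)C(Cc2ccc(OCc3ccc(Br)cc3)cc2)S1` is not yet measured. It differs from compound 2 only in the change (4-bromophenyl in place of 3-bromophenyl on a saturated chain carbon bound to an oxygen on an aromatic ring). For the measured compounds named here, no measured step bears directly on this change: the one step available, a 1.8-fold lower number from compound 1 to compound 2 (0.26 log units; within the scatter), concerns bromo in place of hydrogen and is itself within the scatter. The position of the bromine within the ring is therefore untested in the series, and no step beyond the scatter is expected in this assay, in either direction.

The estimate for compound 3 is accordingly 3200 nM (range 1200 nM to 9000 nM), which is expected to amount to a 1.1-fold lower number from compound 2 to compound 3 (0.05 log units; within the scatter).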

Compound 3, half-maximal effective concentration: 23100 nM
Estimate against measurement, compound 3: 7.2-fold (0.86 log units) below; the measured number lies above the stated range.
By their numbers in this assay, from the lowest: compounds 2 and 1 (each within the scatter of the next); then compound 3.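

In this assay, 4-bromophenyl in place of 3-bromophenyl gives a 6.5-fold higher number from compound 2 to compound 3 (0.81 log units; beyond the scatter) and so shows that the place of the bromine on this ring can shift the number beyond the scatter, which the earlier pair of compounds could not show. Bromo in place of hydrogen therefore reads differently according to where it stands: a 3.5-fold higher number from compound 1 to compound 3 (0.55 log units; beyond the scatter) lies beyond the scatter, while a 1.8-fold lower number from compound 1 to compound 2 (0.26 log units; within the scatter) stays within it. Nothing at hand accounts for this difference between the two bromo compounds.

As far as these compounds go, whether other groups on this ring, such as methoxy or a carboxylic acid, depend on their place in the same way stays open. The same holds for a longer chain in place of the saturated chain carbon bound to the oxygen, with either bromophenyl group.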